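The source may report more compounds than this note shows. Statements on the series, on what has been measured and on what is new or still open speak of the compounds shown alone.

Compound 1 `CCCCCCOc1c(-c2cc(OC)c(OC)c(OC)c2)oc2ccccc2c1=O`: > 50000 nM
Compound 2 `CCCCN(CCCC)CCCOc1c(-c2cc(OC)c(OC)c(OC)c2)oc2ccccc2c1=O`: 15700 nM

In a functional assay on DU-145 cells (Homo sapiens) for antiproliferative activity, read by WST assay, with a stated time of 3 days (on this read-out lower numbers stand for stronger inhibition and higher numbers for weaker inhibition), compound 1 gives only a limit, > 50000 nM, not a measured number. Compound 2, by contrast, gives 15700 nM. Among the compounds with values here, the single measured step, an at least 3.1-fold lower number from compound 1 to compound 2 (0.50 log units; beyond the scatter), therefore runs toward stronger inhibition, and its true size is bounded by the limit of > 50000 nM in this assay, at which 1 of the 2 values shown sits. Compound 3 `CCCCCN(CCCCC)CCCCCOc1c(-c2cc(OC)c(OC)c(OC)c2)oc2ccccc2c1=O` has not yet been measured; it differs from compound 1 by dipentylamino in place of methyl on a saturated chain carbon, five bonds along the chain from an oxygen on an aromatic ring. This resembles the change from compound 1 to compound 2, which likewise brought in a dialkylamino group on the saturated chain, so a step of broadly similar size and direction is expected in this assay. For compound 3 the expected value is 15000 nM, with a range from 4000 nM to 60000 nM. The step of an at least 3.3-fold lower number from compound 1 to compound 3 (0.52 log units; beyond the scatter) is thus estimated to be of the same order as the measured one, while noting that compound 1 supplies only a limit as the starting point.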

Compound 3, half-maximal inhibitory concentration: 11700 nM
Compound 3: the middle estimate sits 1.3-fold (0.11 log units) above what was measured; low and high end bracket the measured number.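

In this assay, dipentylamino in place of methyl on a saturated chain carbon, five bonds along the chain from an oxygen on an aromatic ring, gives an at least 4.2-fold lower number from compound 1 to compound 3 (0.63 log units; beyond the scatter). The lower number seen with the dibutylamino group of compound 2 is therefore not confined to that one amine: a second dialkylamino group, on a different chain, also moves the read-out toward stronger inhibition, and no compound shown goes against this. The true size of the step stays unknown because its starting point is not a number: the limit of > 50000 nM in this assay, at which 1 of the 3 values shown sits.

From the compounds shown here alone, compound 2 and compound 3 differ from each other in both the amine and the chain, so the share of each change remains open. Also open, going by these compounds, is what a smaller amine such as dimethylamino, a ring amine such as piperidine, or a carboxylic acid at the chain end would do.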